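A few compounds are considered here, and "the series" means these few. Any claim that something is new, unique, unknown or untested is made for them only; others in the source may bear on it.

Measured compounds:
compound 1 `SC1=NNCC(n2c(-c3ccco3)nc3ccccc32)=N1` 60500 nM
compound 2 `O=C(Cn1c(-c2ccco2)nc2ccccc21)N/N=C/c1ccccc1Cl` 26100 nM
compound 3 `N#C/C(=C1/SCC(=O)N1c1ccccc1)n1c(-c2ccco2)nc2ccccc21` 55900 nM

Among these three, compound 1 has the highest number in a functional assay on MCF7 cells (Homo sapiens) for cytotoxicity, read by sulforhodamine B assay, with a stated time of 48 h; a higher number here means a weaker inhibitor, a lower number a stronger inhibitor. Compound 3 sits close to it, within the usual scatter, whereas compound 2 lies beyond the scatter on the lower side. Compound 4 `N=C(Cn1c(-c2ccco2)nc2ccccc21)NN` differs from compound 1 in one place: a group of 5 heavy atoms (2 carbon, 3 nitrogen; no ring) in place of a group of 7 heavy atoms (3 carbon, 3 nitrogen, 1 sulfur; one six-membered non-aromatic ring with 3 hetero atoms), on an aromatic nitrogen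

For the measured compounds named here, no step between two measured compounds is available for this change, so the expectation rests on the narrow spread of the three values, all of which are weak. The account expects no step beyond the scatter, with the number of compound 4 estimated near that of compound 1, as a 1.1-fold lower number from compound 1 to compound 4 (0.04 log units; within the scatter). Compound 4 is expected to give about 55000 nM in this assay, in a range from 20000 nM to 150000 nM.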

Compound 4, half-maximal inhibitory concentration: 53100 nM
The estimate for compound 4 lay 1.0-fold (0.02 log units) above the measured number; the measured number falls inside the stated range.
By their numbers in this assay, from the lowest: compound 2; then compounds 4, 3 and 1 (each within the scatter of the next).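

Swapping the six-membered non-aromatic ring with 3 hetero atoms for a group with no ring, on the aromatic nitrogen of the shared core, gives in this assay a 1.1-fold lower number from compound 1 to compound 4 (0.06 log units; within the scatter). This is the only step shown at this position, and it indicates that neither the ring nor its sulfur is needed to hold the number at this level. Nothing shown explains this result.

From the compounds shown here alone, it remains open whether a carboxylic acid or a primary amine on this aromatic nitrogen would give a number beyond the scatter. Going by these compounds, the role of the furan-2-yl group also remains open.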